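Cytotoxicity Limits for Three Measured Compounds and a Fourth

The source may hold more compounds than are shown below. What is called first, only, known or untested is meant among the compounds shown, and "the series" means these compounds.

compound 1 `O=[N+]([O-])c1cn2c(n1)OC[C@@H](OCc1ccc(-c3ccc(OC(F)(F)F)cc3)cc1F)C2`: > 128000 nM
compound 2 `O=[N+]([O-])c1cn2c(n1)OC[C@@H](OCc1ccc(-c3ccc(OC(F)(F)F)cc3)cc1C(F)(F)F)C2`: > 128000 nM
compound 3 `O=[N+]([O-])c1cn2c(n1)OCC(COc1ccc(-c3ccc(C(F)(F)F)cc3)cn1)C2`: > 128000 nM

In an ADME assay on Vero cells (Chlorocebus sabaeus) for cytotoxicity, with a stated time of 72 h (a lower number here means a stronger inhibitor, a higher number a weaker inhibitor), compound 1 gives > 128000 nM, which is a limit of the assay and not a number. Compound 2 gives > 128000 nM, also a limit. Compound 3 gives > 128000 nM, again a limit. All three values therefore sit at the limit of > 128000 nM in this assay, at which 3 of the 3 values shown sit. Compound 1 differs from compound 2 by fluoro in place of trifluoromethyl on an aromatic carbon, and the step that the two limits leave unreadable from compound 2 to compound 1 cannot be read, since both ends are limits. The difference between the cores of compound 2 and compound 3 is not broken down here. Compound 4 `O=[N+]([O-])c1cn2c(n1)OCC(COc1ccc(-c3ccc(F)cc3)cn1)C2` has not yet been measured; it differs from compound 3 by fluoro in place of trifluoromethyl on an aromatic carbon. This is the same kind of change as from compound 2 to compound 1, though the place is not the same: in compound 1 the fluoro sits ortho to a large group and meta to a 4-(trifluoromethoxy)phenyl group, whereas in compound 4 it sits para to a large group. Because compound 3 gives only the limit > 128000 nM, and because the earlier step that the two limits leave unreadable from compound 2 to compound 1 is unreadable, compound 4 is expected to stay at or around the limit, estimated at 150000 nM with a range from 100000 nM to 300000 nM. The expected step from compound 3 is thus a step that the limit leaves unreadable from compound 3 to compound 4, most likely reported only as a limit.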

Compound 4, half-maximal inhibitory concentration: > 128000 nM
Compound 4: no number, only a limit; the forecaster's own chance of this, stated with the estimate: 85%; the middle value does not contradict the limit.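

In this assay compound 4 gives > 128000 nM, which is a limit of the assay and not a number. The step from compound 3 to compound 4 therefore cannot be read, and no compound separates from the others: the limit of > 128000 nM in this assay, at which 4 of the 4 values shown sit.

The compounds shown leave open whether fluoro in place of trifluoromethyl changes cytotoxicity at all.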